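This account rests on a few compounds, and the source may have more. Where it says the series, first, only, none or still open, it means among the compounds named here.

Compound 1 `COc1cc2c(Oc3ccc(NC(=O)c4nn(-c5ccc(Br)cc5)c(=O)c5ccccc45)cc3F)ccnc2cc1OCCCN1CCCC1`: 670 nM
Compound 2 `COc1cc2c(Oc3ccc(NC(=O)c4nn(-c5ccccc5Br)c(=O)c5ccccc45)cc3F)ccnc2cc1OCCCN1CCCC1`: 850 nM
Compound 3 `COc1cc2c(Oc3ccc(NC(=O)c4nn(-c5ccc([N+](=O)[O-])cc5)c(=O)c5ccccc45)cc3F)ccnc2cc1OCCCN1CCCC1`: 1760 nM

All three were tested in a functional assay on HT-29 cells (Homo sapiens) for cytotoxicity, read by MTT assay, with a stated time of 72 h; on this read-out lower numbers stand for stronger inhibition and higher numbers for weaker inhibition. On these numbers compound 2 stands second highest of three; its nearest neighbour is compound 1, with a 1.3-fold higher number from compound 1 to compound 2 (0.10 log units; within the scatter), and its furthest is compound 3, with a 2.1-fold higher number from compound 2 to compound 3 (0.32 log units; beyond the scatter). Compound 4 `COc1cc2c(Oc3ccc(NC(=O)c4nn(-c5ccccc5Br)c(=O)c5ccccc45)cc3F)ccnc2cc1OCCCN1CCN(C)CC1` differs from compound 2 in one place: 4-methylpiperazin-1-yl in place of pyrrolidin-1-yl on a saturated chain carbon, three bonds along the chain from an oxygen on an aromatic ring. For the measured compounds named here, no measured step touches this part of the structure; a 1.3-fold higher number from compound 1 to compound 2 (0.10 log units; within the scatter) and a 2.6-fold higher number from compound 1 to compound 3 (0.42 log units; beyond the scatter) both alter the group on the aromatic nitrogen, while the pyrrolidin-1-yl on the saturated chain is shared by all three. With nothing measured that bears on this change, no step beyond the scatter is expected in this assay; the expected step is no change at the digits printed from compound 2 to compound 4 (within the scatter). Compound 4 is therefore estimated at 850 nM, within a range from 350 nM to 2100 nM.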

Compound 4, half-maximal inhibitory concentration: 1190 nM
Beside the measured number, compound 4's estimate is 1.4-fold (0.15 log units) below it; the measured number falls inside the stated range.
By their numbers in this assay, from the lowest: compounds 1, 2, 4 and 3 (each within the scatter of the next, the first and the last beyond it).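

The swap from pyrrolidin-1-yl to 4-methylpiperazin-1-yl gives a 1.4-fold higher number from compound 2 to compound 4 (0.15 log units; within the scatter) in this assay and is the first change shown at the far end of the chain. At this position, with the 2-bromophenyl group in place, a six-membered ring with a second nitrogen leaves the number within the scatter of the five-membered ring. Nothing available offers an explanation for this result.

Still open, on these data alone, is how a morpholine ring or a dimethylamino group would read at the end of the same chain, or either amine on a shorter ethyl chain. Also open, as far as these compounds go, is whether 4-methylpiperazin-1-yl gives a similar step when paired with the 4-bromophenyl group of compound 1 or the 4-nitrophenyl group of compound 3.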